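The source may report more compounds than this note shows. Statements on the series, on what has been measured and on what is new or still open speak of the compounds shown alone.

Going by the values given here, in a functional assay on C6 cells (Rattus norvegicus) for inhibition, read by sulforhodamine B assay, with a stated time of 72 h (on this read-out higher numbers stand for an effect only at larger amounts of compound and lower numbers for an effect already at smaller amounts), three compounds have numbers so far. Compound 1 (`O=C(/C=C/c1ccc([N+](=O)[O-])o1)c1ccc(N2CCCCC2)cc1`) gives 48700 nM, compound 2 (`O=C(/C=C/c1ccc([N+](=O)[O-])s1)c1ccc(-n2ccnc2)cc1`) gives 1900 nM, and compound 3 (`O=C(/C=C/c1ccc(Cl)s1)c1ccc(-n2ccnc2)cc1`) gives 14500 nM. This makes compound 3 the second highest of the three, closer to compound 1 than to compound 2.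

Compound 4 (`O=C(/C=C/c1ccc(Cl)s1)c1ccc(N2CCCCC2)cc1`) has not yet been measured. It has piperidin-1-yl in place of 1H-imidazol-1-yl on an aromatic carbon, para to a large group: piperidin-1-yl in place of 1H-imidazol-1-yl on an aromatic carbon. Among the compounds with values here, no measured step makes this exchange on its own. Within the data shown here, the only measured step, a 7.6-fold higher number from compound 2 to compound 3 (0.88 log units; beyond the scatter), lies at a different place in the molecule, so it sets no direct size for this change. Among the measured compounds shown here, the one indirect hint comes from compound 1, the only measured compound with piperidin-1-yl, which has the highest number at 48700 nM. However, compound 1 differs from compound 3 in more than one place, so this hint is weak and the range must stay wide.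

A modest step towards a higher number is therefore expected in this assay. The expected change is a 2.1-fold higher number from compound 3 to compound 4 (0.32 log units; beyond the scatter). Compound 4 is estimated at 30000 nM, with an expected range from 9000 nM to 90000 nM.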

Compound 4, half-maximal effective concentration: 36600 nM
Estimate against measurement, compound 4: 1.2-fold (0.09 log units) below; low and high end bracket the measured number.
By their numbers in this assay, from the lowest: compound 2; then compound 3; then compounds 4 and 1 (each within the scatter of the next).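

In this assay the exchange of 1H-imidazol-1-yl for piperidin-1-yl, on an aromatic carbon para to a large group, now has a direct size: with the 5-chlorothiophen-2-yl end unchanged, it gives a 2.5-fold higher number from compound 3 to compound 4 (0.40 log units; beyond the scatter) and so moves the number beyond the scatter at this position. With piperidin-1-yl held in place, 5-chlorothiophen-2-yl in place of 5-nitrofuran-2-yl gives a 1.3-fold lower number from compound 1 to compound 4 (0.12 log units; within the scatter) and so leaves no readable difference, whereas the earlier step at that end, a 7.6-fold higher number from compound 2 to compound 3 (0.88 log units; beyond the scatter), is a different exchange made with 1H-imidazol-1-yl in place. No evidence on the reason for either step is available here.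

The size of the change from 1H-imidazol-1-yl to piperidin-1-yl rests on this single pair, so the compounds shown do not tell whether it would be the same with a nitro group at the other end of the molecule. They also leave open where a morpholine ring, a dimethylamino group or a carboxylic acid at this position would fall relative to compound 3 and compound 4.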